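Series notes: heteroarylmethyl groups on the ring amine

This account rests on a few compounds, and the source may have more. Where it says the series, first, only, none or still open, it means among the compounds named here.

Measured so far in an assay on isolated protein for activation of cGMP-dependent protein kinase 1 (Homo sapiens), read by ADP-Glo, with stated times of 120 min and 40 min; on this read-out higher numbers stand for an effect only at larger amounts of compound and lower numbers for an effect already at smaller amounts:
compound 1 `Clc1cc(Cl)cc(CO[C@H]2CCCN(Cc3ncco3)[C@H]2c2ccccc2)c1` gives > 200000 nM, a limit of the assay only.
compound 2 `Clc1cc(Cl)cc(CO[C@H]2CCCN(Cc3ncc[nH]3)[C@H]2c2ccccc2)c1` gives 47000 nM.

Compound 2 holds the only number shown; the other value is a limit (the limit of > 200000 nM in this assay, at which 1 of the 2 values shown sits). Going by the values given here, the step of an at least 4.2-fold lower number from compound 1 to compound 2 (0.62 log units; beyond the scatter) is the only measured step. Compound 3 `Clc1cc(Cl)cc(CO[C@H]2CCCN(Cc3cccnc3)[C@H]2c2ccccc2)c1` carries pyridin-3-yl in place of 1H-imidazol-2-yl on a saturated chain carbon bound to an amine nitrogen in a ring. Since the donor-free analogue compound 1 sat at the limit, a weaker result is expected for compound 3, with a 2.6-fold higher number from compound 2 to compound 3 (0.41 log units; beyond the scatter) as the estimated step. Compound 3 is estimated at 120000 nM in this assay, between 40000 nM and 300000 nM.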

Compound 3, half-maximal effective concentration: 112000 nM
Beside the measured number, compound 3's estimate is 1.1-fold (0.03 log units) above it; low and high end bracket the measured number.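

Replacing 1H-imidazol-2-yl with pyridin-3-yl gives a 2.4-fold higher number from compound 2 to compound 3 (0.38 log units; beyond the scatter) in this assay. Compound 3 has no hydrogen-bond donor in this group yet still gives a number rather than a limit, so a donor is not required for a reading at this place. Replacing 1,3-oxazol-2-yl with pyridin-3-yl gives an at least 1.7-fold lower number from compound 1 to compound 3 (0.25 log units; that floor lies within the scatter), and this comparison rests on a limit: the limit of > 200000 nM in this assay, at which 1 of the 3 values shown sits.

As far as these compounds go, what a plain phenyl or a 1H-imidazol-4-yl group would give here stays open. So does the effect of a longer chain between the ring amine and the aromatic ring.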